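Bromo for fluoro on the aryl ring of compound 2

The source may report more compounds than this note shows. Statements on the series, on what has been measured and on what is new or still open speak of the compounds shown alone.

Of the compounds shown here, two with a shared core have been measured in a functional assay on HT-29 cells (Homo sapiens) for cytotoxicity, read by MTT assay, with a stated time of 72 h; a higher number here means a weaker inhibitor, a lower number a stronger inhibitor. Compound 1 `COc1cc2c(Oc3ccc(NC(=O)c4nn(-c5ccc(Br)cc5)c(=O)c5ccccc45)cc3F)ccnc2cc1OCCCN1CCN(C)CC1` gives 850 nM in this assay. Compound 2 `COc1cc2c(Oc3ccc(NC(=O)c4nn(-c5ccc(F)cc5)c(=O)c5ccccc45)cc3F)ccnc2cc1OCCCN1CCC(C)CC1` gives 330 nM in this assay, the lower of the two numbers, and the gap to compound 1 lies beyond the usual scatter. Compound 1 differs from compound 2 in more than one place, so the two values alone do not show what any single change contributes.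

Compound 3 `COc1cc2c(Oc3ccc(NC(=O)c4nn(-c5ccc(Br)cc5)c(=O)c5ccccc45)cc3F)ccnc2cc1OCCCN1CCC(C)CC1` has not yet been measured. It differs from compound 2 by bromo in place of fluoro on an aromatic carbon. Going by the values given here, with no single-change step between measured compounds, the expected size of this step is uncertain; a small weakening or no change beyond the scatter seems most likely. Compound 3 is therefore estimated at 450 nM in this assay, within 200 nM to 1000 nM, which means an expected step of a 1.4-fold higher number from compound 2 to compound 3 (0.13 log units; within the scatter).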

Compound 3, half-maximal inhibitory concentration: 920 nM
Compound 3: middle estimate off by 2.0-fold (0.31 log units), on the low side; the range from low to high includes it.
By their numbers in this assay, from the lowest: compound 2; then compounds 1 and 3 (each within the scatter of the next).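

In this assay, going by these compounds alone, bromo in place of fluoro on the aromatic carbon gives a 2.8-fold higher number from compound 2 to compound 3 (0.45 log units; beyond the scatter), the first reading of a single change at this position, and the step, though modest, lies beyond the scatter in favour of the 4-fluorophenyl group. At the end of the chain, 4-methylpiperidin-1-yl in place of 4-methylpiperazin-1-yl gives a 1.1-fold higher number from compound 1 to compound 3 (0.03 log units; within the scatter), so with the 4-bromophenyl group these two rings cannot be told apart in this assay. Of the two single changes, then, only the halogen swap registers here, though each rests on one pair of compounds.

The values shown give no reason for either step. Still open, from the compounds shown here alone, are how chloro or methoxy would read on the same aromatic carbon, and whether a morpholine at the chain end, or the piperazine alongside the 4-fluorophenyl group, would read the same way.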